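Losing the carboxy group from the lowest-clearance compound

The source may report more compounds than this note shows. Statements on the series, on what has been measured and on what is new or still open speak of the compounds shown alone.

- Compound 1 `CCc1cc(C(F)(F)F)c2cccc(OCc3c(Cl)ccc(S(=O)(=O)N4CCC[C@H]4C(=O)NC)c3Cl)c2n1` gives 1280 mL/min/kg 
- Compound 2 `Cc1cc(C(F)(F)F)c2cccc(OCc3c(Cl)ccc(S(=O)(=O)N4CCC[C@H]4C(N)=O)c3Cl)c2n1` gives 12600 mL/min/kg 
- Compound 3 `Cc1cc(C(F)(F)F)c2cccc(OCc3c(Cl)ccc(S(=O)(=O)N4CCC[C@H]4C(=O)O)c3Cl)c2n1` gives 13.3 mL/min/kg 

All three were measured in an ADME assay on microsomes (Mus musculus) for metabolic stability (on this read-out lower numbers stand for slow clearance and higher numbers for fast clearance), and they share much of one structure. Compound 3 holds the lowest of the three numbers, and compound 1 and compound 2 both lie beyond the scatter above it. It is also the only one of the three that carries a carboxy group.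

The next compound, compound 4 `COC[C@@H]1CCCN1S(=O)(=O)c1ccc(Cl)c(COc2cccc3c(C(F)(F)F)cc(C)nc23)c1Cl`, has methoxymethyl in place of carboxy on a saturated ring carbon and is otherwise the same as compound 3.

Among the measured compounds shown here, no measured compound carries methoxymethyl, so the closest evidence is indirect. Hydroxy in place of amino on a carbonyl carbon gave a 950-fold lower number from compound 2 to compound 3 (2.98 log units; beyond the scatter) and counts as a large step. The other compound without a carboxy group, compound 1, also stands high at 1280 mL/min/kg in the same read-out, though it differs from compound 3 in more than one place.

Both observations suggest a large rise in this assay once the carboxy group is gone. The expected change is a 110-fold higher number from compound 3 to compound 4 (2.05 log units; beyond the scatter) on this estimate. Compound 4 is estimated at 1500 mL/min/kg with a range of 200 mL/min/kg to 9000 mL/min/kg as the expected span.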

Compound 4, clearance: 1620 mL/min/kg
Beside the measured number, compound 4's estimate is 1.1-fold (0.03 log units) below it; the range from low to high includes it.
By their numbers in this assay, from the lowest: compound 3; then compounds 1 and 4 (each within the scatter of the next); then compound 2.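

In this assay, the swap of carboxy for methoxymethyl on this saturated ring carbon gives a 120-fold higher number from compound 3 to compound 4 (2.09 log units; beyond the scatter) with nothing else in the structure altered, so a second replacement at this position now ends far above the carboxy compound. Until now, only the carbamoyl group had been compared with carboxy here, whereas among compounds 2, 3 and 4 the low number now stays with carboxy alone across two different replacements. The groups without carboxy are not interchangeable either, as going to methoxymethyl from carbamoyl gives a 7.8-fold lower number from compound 2 to compound 4 (0.89 log units; beyond the scatter) in the same read-out, although the compounds shown offer no information on why these numbers differ.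

Going by these compounds, it remains open whether the low number needs a carboxy group attached directly to this ring carbon, or whether a tetrazole or a carboxymethyl chain at the same place would also give it. A hydroxymethyl group, which differs from methoxymethyl by keeping a hydrogen on its oxygen, is also an untested case, and it could fall nearer to compound 3 or to compound 4.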